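Swapping an aryl group on a statin-like dihydroxy acid

A few compounds are considered here, and "the series" means these few. Any claim that something is new, unique, unknown or untested is made for them only; others in the source may bear on it.

Measured so far:
- compound 1, `CC[C@H](C)C(=O)O[C@H]1C[C@@H](C)C=C2C=C[C@H](C)[C@H](CC[C@@H]3C[C@@H](O)CC(=O)O3)[C@]21C`: 3 nM
- compound 2, `COc1ccc(-c2nc(C(F)(F)F)n(CC[C@@H](O)C[C@@H](O)CC(=O)O)c2-c2ccc(F)cc2)cc1`: 68 nM

Both numbers come from an assay on microsomes from liver for inhibition of 3-hydroxy-3-methylglutaryl-coenzyme A reductase (Rattus norvegicus); a higher number here means a weaker inhibitor, a lower number a stronger inhibitor. Compound 1 is a natural-product-type lactone and in this assay compound 1 gives 3 nM. Compound 2 is a synthetic open-chain dihydroxy acid carrying a five-membered ring with two nitrogens, and in this assay compound 2 gives 68 nM. Of the two numbers, that of compound 2 is the higher one, and the gap to compound 1 is beyond the usual scatter, so compound 2 is the weaker inhibitor of the two.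

Compound 3, `O=C(O)C[C@H](O)C[C@H](O)CCn1c(C(F)(F)F)nc(-c2cccs2)c1-c1ccc(F)cc1`, is the unmeasured neighbour of compound 2. The change is thiophen-2-yl in place of 4-methoxyphenyl on an aromatic carbon. Going by the values given here, no pair of measured compounds shows the effect of this kind of swap, so the step has to be guessed from the structures alone. The aryl group moves from a six-membered carbon ring to a smaller sulfur-containing ring while everything else, including the dihydroxy acid chain, stays the same. The step from compound 2 to compound 3 is expected to be small, a 1.1-fold lower number from compound 2 to compound 3 (0.05 log units; within the scatter), likely within the scatter. Compound 3 is therefore expected to give 60 nM, within a range of 20 nM to 200 nM.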

Compound 3, half-maximal inhibitory concentration: 64 nM
Compound 3: middle estimate off by 1.1-fold (0.03 log units), on the low side, within the range that was stated.
By their numbers in this assay, from the lowest: compound 1; then compounds 3 and 2 (each within the scatter of the next).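

In this assay, putting thiophen-2-yl in place of 4-methoxyphenyl gives a 1.1-fold lower number from compound 2 to compound 3 (0.03 log units; within the scatter), so the two compounds cannot be told apart in this test. Going by these compounds alone, this is the only measured pair that changes this aromatic carbon, and it shows that the group there can go from a six-membered aromatic ring of carbon only, with 8 heavy atoms, to a five-membered aromatic ring with a sulfur, with 5 heavy atoms, without a measurable shift in the number. Nothing measured here explains why the two groups read alike.

One swap cannot show how much freedom this position allows overall, and a group of a different kind, such as an amine, a carboxylic acid or a longer alkyl chain, could behave quite differently at the same carbon. As far as these compounds go, it also remains open whether thiophen-2-yl and 4-methoxyphenyl would still match if the neighbouring 4-fluorophenyl group or the trifluoromethyl group were replaced by something else.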